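A chloro step from compound 1 to compound 4

The source may report more compounds than this note shows. Statements on the series, on what has been measured and on what is new or still open speak of the compounds shown alone.

In a functional assay on MCF7 cells (Homo sapiens) for inhibition, read by MTT assay (on this read-out lower numbers stand for stronger inhibition of growth and higher numbers for weaker inhibition of growth), compound 1 `COc1cc2oc(-c3cccc(NC(=O)c4ccccc4)c3)cc(=O)c2c(OC)c1OC` gives 12100 nM. Compound 2 `COc1cc2oc(-c3cccc(NC(=O)c4cccc(Br)c4)c3)cc(=O)c2c(OC)c1OC`, at 6340 nM, lies within the scatter of it, while compound 3 `COc1cc2oc(-c3cccc(NC(=O)c4ccccc4Br)c3)cc(=O)c2c(OC)c1OC`, at 55000 nM, has the highest number of the three. Compound 1 therefore stands with compound 2, and compound 3 lies clearly above both.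

Compound 4 `COc1cc2oc(-c3cccc(NC(=O)c4ccc(Cl)cc4)c3)cc(=O)c2c(OC)c1OC` has not yet been measured. It differs from compound 1 by chloro in place of hydrogen on an aromatic carbon, para to a large group, turning benzoyl into (4-chlorophenyl)carbonyl.

The closest evidence comes from two steps that put bromo in place of hydrogen on the same ring: a 1.9-fold lower number from compound 1 to compound 2 (0.28 log units; within the scatter), and a 4.5-fold higher number from compound 1 to compound 3 (0.66 log units; beyond the scatter). The two bromo compounds differ only in where the bromo sits, and that gives an 8.7-fold higher number from compound 2 to compound 3 (0.94 log units; beyond the scatter). Among the compounds with values here, no measured compound carries chloro, or any group at the place it occupies in compound 4, so this evidence is only indirect. The expectation follows the smaller step, a 1.9-fold lower number from compound 1 to compound 2 (0.28 log units; within the scatter), and no change beyond the scatter is expected, with a slight lean towards a lower number. The expected change is a 1.3-fold lower number from compound 1 to compound 4 (0.11 log units; within the scatter). For compound 4 the estimate is 9500 nM, with an expected range of 4000 nM to 25000 nM.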

Compound 4, concentration for 50% growth inhibition: 8780 nM
Compound 4: middle estimate off by 1.1-fold (0.03 log units), on the high side, within the range that was stated.
By their numbers in this assay, from the lowest: compounds 2, 4 and 1 (each within the scatter of the next); then compound 3.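

In this assay, chloro on the benzoyl ring, para to a large group, is the first substituent shown at this place, and a 1.4-fold lower number from compound 1 to compound 4 (0.14 log units; within the scatter) indicates that the change leaves the read-out near that of the unsubstituted compound. Against the bromo compounds, the comparison gives a 1.4-fold higher number from compound 2 to compound 4 (0.14 log units; within the scatter) and a 6.3-fold lower number from compound 3 to compound 4 (0.80 log units; beyond the scatter) so that, of the four compounds, only compound 3 stands apart from the others, although these two steps change both the halogen and its place. Nothing measured here speaks to what lies behind these numbers.

The compounds shown leave open whether chloro and bromo would give the same result at one and the same place, as compound 4 differs from compound 2 and compound 3 in both respects. They also leave open what an amine, a carboxylic acid or a longer chain would do at the place that chloro occupies in compound 4.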